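From Phenyl to 3,5-Dimethoxyphenyl on a Shared Core

The source may report more compounds than this note shows. Statements on the series, on what has been measured and on what is new or still open speak of the compounds shown alone.

- Compound 1 `O=C(CCc1cccc2c1B(O)OC2)Nc1ccc(Cl)cc1`: 3600 nM
- Compound 2 `O=C(CCc1cccc2c1B(O)OC2)Nc1cccc(-c2ccccc2)c1`: 220 nM

In a functional assay on MDA-MB-231 cells (Homo sapiens) for antiproliferative activity, read by MTT assay, with a stated time of 72 h (on this read-out higher numbers stand for weaker inhibition and lower numbers for stronger inhibition), compound 2 gives 220 nM, the lower of the two numbers, while compound 1 gives 3600 nM. The gap between these two numbers lies beyond the scatter. Compound 3 `COc1cc(OC)cc(-c2cccc(NC(=O)CCc3cccc4c3B(O)OC4)c2)c1` differs from compound 2 in one place: 3,5-dimethoxyphenyl in place of phenyl on an aromatic carbon. Going by the values given here, no measured pair of compounds shows what this change does, so little guides the prediction. The estimated step, a 1.1-fold lower number from compound 2 to compound 3 (0.04 log units; within the scatter), is expected to be modest, with no firm direction and possibly nothing beyond the scatter. Compound 3 is expected at 200 nM, with an estimated range from 50 nM to 800 nM.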

Compound 3, half-maximal inhibitory concentration: 40 nM
Beside the measured number, compound 3's estimate is 5.0-fold (0.70 log units) above it; measured number outside the range, below it.
By their numbers in this assay, from the lowest: compound 3; then compound 2; then compound 1.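

In this assay this aromatic carbon, meta to a large group, is a position where the choice of aryl group matters: 3,5-dimethoxyphenyl in place of phenyl brings a 5.5-fold lower number from compound 2 to compound 3 (0.74 log units; beyond the scatter) and so a real gain in antiproliferative strength. The phenyl ring here can therefore carry added methoxy groups without any loss, and with a clear gain. Still open, from the compounds shown here alone, is whether a single methoxy group would be enough, or how an amine or a carboxylic acid on this ring would compare. No measurement shown gives a reason for this step.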